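The compounds below may be only part of what the source reports. "The series", "measured", "known", "first", "only" and "open" are said of these compounds alone.

In a functional assay on the whole organism (strain Wistar) with Rattus norvegicus as the target, with a stated time of 5 min (on this read-out lower numbers stand for an effect already at smaller amounts and higher numbers for an effect only at larger amounts of compound), compound 1 `CCC1(CCCCN2CCN(c3ccc(F)c(Cl)c3)CC2)C(=O)Nc2ccccc21` gives only a limit, > 20 mg/kg. Compound 2 `CCC1(CCCN2CCN(c3cccc(Cl)c3)CC2)C(=O)Nc2ccccc21` likewise returns a limit, > 20 mg/kg. Compound 3 `CCC1(CCCCCN2CCN(c3cccc(Cl)c3)CC2)C(=O)Nc2ccccc21` also sits at a limit, > 10 mg/kg. No value shown in this assay is a number: two sit at the limit of > 20 mg/kg in this assay, at which 2 of the 3 values shown sit, and one at the limit of > 10 mg/kg in this assay, at which 1 of the 3 values shown sits, so compound 1 stands where the other values stand, without a number to rank it. Compound 4 `CCC1(CCCCN2CCN(c3cccc(Cl)c3)CC2)C(=O)Nc2ccccc21` differs from compound 1 in one place: hydrogen in place of fluoro on an aromatic carbon. The chloro and the shared core remain as they are. With every value at a limit, no step beyond the usual scatter is expected in this assay. Compound 4 is expected to give about 20 mg/kg, within 10 mg/kg to 40 mg/kg. The expected step is a number no higher from compound 1 to compound 4 (the limit leaves the size open), with a limit rather than a number the likelier outcome.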

Compound 4, minimum effective dose: > 20 mg/kg
Compound 4: a limit, no number (the forecaster's own chance of this, stated with the estimate: 75%); the middle value lies on the limit itself.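

No step can be read from compound 1 to compound 4 in this assay, since both results are limits rather than numbers. The compounds shown leave open whether fluoro versus hydrogen changes the minimum effective dose at all.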